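The source may hold more compounds than are shown below. What is called first, only, known or untested is meant among the compounds shown, and "the series" means these compounds.

In a functional assay on NCI-H460 cells (Homo sapiens) for inhibition, read by MTT assay, with a stated time of 48 h (a higher number here means a weaker inhibitor, a lower number a stronger inhibitor), compound 1 `O=C(CC(c1ccc(Cl)cc1)C(C(=O)Nc1ccccn1)C(=O)Nc1ccccn1)c1ccccc1` gives 18900 nM and compound 2 `O=C(CC(c1ccc(F)cc1)C(C(=O)Nc1ccccn1)C(=O)Nc1ccccn1)c1ccc(F)cc1` gives 20100 nM, two values within the usual scatter of each other. Compound 3 `O=C(CC(c1cccs1)C(C(=O)Nc1ccccn1)C(=O)Nc1ccccn1)c1ccccc1` has no number to set beside them, since compound 3 is recorded as "not active" (no number reported). Compound 4 `O=C(CC(c1c(Cl)cccc1Cl)C(C(=O)Nc1ccccn1)C(=O)Nc1ccccn1)c1ccccc1` carries 2,6-dichlorophenyl in place of thiophen-2-yl on a saturated chain carbon bound to two saturated chain carbons. In this assay the expected step leads from no number to a measurable but weak inhibition, because compound 1 gives 18900 nM with a chlorine-bearing six-membered aromatic ring on that carbon. Another result without a number remains possible. For compound 4 the estimated value is 25000 nM, with an expected range from 12000 nM to 55000 nM.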

Compound 4, half-maximal inhibitory concentration: 27400 nM
For compound 4 the middle estimate is 1.1-fold (0.04 log units) below the measured one; the measured number falls inside the stated range.
By their numbers in this assay, from the lowest: compounds 1, 2 and 4 (each within the scatter of the next).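

In this assay, placing 2,6-dichlorophenyl in place of 4-chlorophenyl on a saturated chain carbon bound to two saturated chain carbons gives a 1.4-fold higher number from compound 1 to compound 4 (0.16 log units; within the scatter), so these two chlorine-bearing rings cannot be told apart in this measurement. The step from compound 3 to compound 4 cannot be read, since compound 3 has no number. Nothing measured here explains this result. Going by these compounds, it remains open what an unsubstituted phenyl ring or a ring bearing an amine or a carboxylic acid would give at this carbon.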